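Extending the glycine unit: from compound 1 to compound 4

This account rests on a few compounds, and the source may have more. Where it says the series, first, only, none or still open, it means among the compounds named here.

Measured compounds:
compound 1 `O=C(CN(c1nc(Cl)nc2[nH]cnc12)C1CC1)NCC(=O)OCc1ccccc1` 18%
compound 2 `O=C(O)CNC(=O)CN(c1nc(Cl)nc2[nH]cnc12)C1CC1` 9.08%
compound 3 `O=C(O)CC[C@H](NC(=O)CN(c1nc(Cl)nc2[nH]cnc12)C1CC1)C(=O)O` 29.5%

The read-out is a functional assay on the whole organism (Tail, strain ICR) with Mus musculus as the target, in the tail flick test, with a stated time of 150 min, at a dose of 25 umol/kg by the oral route; on this read-out higher numbers stand for a stronger effect at the one dose given and lower numbers for a weaker effect. Compound 1 stands second highest of the three numbers; compound 2 lies closest to it, and compound 3 lies furthest from it at the higher end. Compound 4 `CSCC[C@H](NC(=O)CN(c1nc(Cl)nc2[nH]cnc12)C1CC1)C(=O)OCc1ccccc1` is not yet measured. It differs from compound 1 by 2-(methylsulfanyl)ethyl in place of hydrogen on a saturated chain carbon bound to an amide-type nitrogen and a carbonyl carbon.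

Of the measured steps, a number 20.4 percentage points higher from compound 2 to compound 3 (beyond the scatter) bears most directly on this change, since it also adds a chain at the same place, albeit a different one. The other step, a number 8.9 percentage points lower from compound 1 to compound 2 (within the scatter), changes a different part of the molecule and stays within the scatter. Taken together, a modest rise is expected, though the new chain differs from the one in compound 3 and the pair shares no measured step, so the range is wide.

For compound 4 the expected value in this assay is 28%, between 12% and 45%. This estimate means a step of a number 10 percentage points higher from compound 1 to compound 4 (within the scatter), expected to be modest.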

Compound 4, a percentage reported as activity, at one dose (the size of the read-out at that dose, not a potency): 17.6%
For compound 4 the middle estimate is 10.4 percentage points above the measured one, within the range that was stated.
By their numbers in this assay, from the lowest: compounds 2, 4 and 1 (each within the scatter of the next); then compound 3.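

In this assay, placing 2-(methylsulfanyl)ethyl on the saturated chain carbon bound to an amide-type nitrogen and a carbonyl carbon gives a number 0.4 percentage points lower from compound 1 to compound 4 (within the scatter). Among the compounds shown here, this position therefore carries this chain on the benzyl ester without the read-out leaving the scatter, whereas the only earlier step at this place, with 2-carboxyethyl on the free acid, gave a number 20.4 percentage points higher from compound 2 to compound 3 (beyond the scatter), so a chain here does not by itself go with a higher number. No measured evidence is available to explain why these two steps read differently.

The compounds shown leave open how 2-(methylsulfanyl)ethyl reads on the free acid and 2-carboxyethyl on the benzyl ester, which would separate the role of the chain from that of the ester or acid end. Also open, on these data alone, is how a methyl group, or a longer chain ending in an amine, would read at this carbon.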